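A few compounds are considered here, and "the series" means these few. Any claim that something is new, unique, unknown or untested is made for them only; others in the source may bear on it.

Compound 1 `COc1ccc([C@@H]2CC(=O)c3c(O)cc(OCc4cn(Cc5cccc(Cl)c5)nn4)cc3O2)cc1O` carries a 3-chlorophenyl group on a saturated chain carbon bound to an aromatic nitrogen. Among the measured compounds shown here, in a functional assay on RAW264.7 cells (Mus musculus) for inhibition, read by Griess assay, with stated times of 2 h and 24 h (a higher number here means a weaker inhibitor, a lower number a stronger inhibitor), compound 1 gives 18200 nM, the highest of the three numbers measured so far. Compound 2 `COc1ccc([C@@H]2CC(=O)c3c(O)cc(OCc4cn(CC5CC5)nn4)cc3O2)cc1O` differs from compound 1 only in that group; in this assay compound 2 gives 11900 nM, and the step is a 1.5-fold lower number from compound 1 to compound 2 (0.18 log units; within the scatter). Compound 3 `COc1ccc([C@@H]2C/C(=N\O)c3c(O)cc(OCc4cn(-c5ccccc5)nn4)cc3O2)cc1O` gives 6130 nM in this assay, but it differs from compound 1 in two places and so offers no single-change comparison.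

Compound 4 `CCCCn1cc(COc2cc(O)c3c(c2)O[C@H](c2ccc(OC)c(O)c2)CC3=O)nn1` has not yet been measured. It differs from compound 1 in one place: propyl in place of 3-chlorophenyl on a saturated chain carbon bound to an aromatic nitrogen. For the measured compounds named here, the only step that bears on this change is the one from compound 1 to compound 2, where cyclopropyl took the place of the 3-chlorophenyl group and the number moved only within the scatter. A step of similar size is therefore expected here, a 1.5-fold lower number from compound 1 to compound 4 (0.18 log units; within the scatter), a slight lowering at most or none beyond the scatter. Compound 4 is accordingly expected to give 12000 nM in this assay, with a likely range from 5000 nM to 30000 nM.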

Compound 4, half-maximal inhibitory concentration: 13900 nM
For compound 4 the middle estimate is 1.2-fold (0.06 log units) below the measured one; the range from low to high includes it.
By their numbers in this assay, from the lowest: compounds 3, 2, 4 and 1 (each within the scatter of the next, the first and the last beyond it).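

In this assay, among the compounds shown here, compound 4 brings an open chain to a place so far held only by ring groups: propyl in place of 3-chlorophenyl, on a saturated chain carbon bound to an aromatic nitrogen, gives a 1.3-fold lower number from compound 1 to compound 4 (0.12 log units; within the scatter) and so no change that can be told from scatter. Propyl in place of cyclopropyl gives a 1.2-fold higher number from compound 2 to compound 4 (0.07 log units; within the scatter) and likewise no readable change. Compounds 1, 2 and 4 therefore cannot be told apart, although the group at this place can be 3-chlorophenyl, cyclopropyl or propyl.

From the compounds shown here alone, whether an amine or a carboxylic acid at this place would move the number beyond the scatter stays open. Nothing available explains why these three groups give such similar numbers.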